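Cytotoxicity series on one shared core; one step untested

The compounds below may be only part of what the source reports. "The series", "measured", "known", "first", "only" and "open" are said of these compounds alone.

Measured so far:
compound 1 `O=C(N/N=C/c1ccc(O)cc1O)Nc1cc2c(Nc3ccc(F)c(Cl)c3)ncnc2cc1O[C@H]1CCOC1` — 4530 nM
compound 2 `CCN(CC)c1ccc(/C=N/NC(=O)Nc2cc3c(Nc4ccc(F)c(Cl)c4)ncnc3cc2O[C@H]2CCOC2)c(O)c1` — 15700 nM
compound 3 `COc1cc2ncnc(Nc3ccc(F)c(Cl)c3)c2cc1NC(=O)N/N=C/c1ccc(O)cc1O` — 32100 nM

In a functional assay on HepG2 cells (Homo sapiens) for cytotoxicity, read by MTT assay, with a stated time of 72 h (a higher number here means a weaker inhibitor, a lower number a stronger inhibitor), compound 1 gives 4530 nM. Compound 2 gives 15700 nM, the step being a 3.5-fold higher number from compound 1 to compound 2 (0.54 log units; beyond the scatter); the change is diethylamino in place of hydroxy on an aromatic carbon. Compound 3 gives 32100 nM after a 7.1-fold higher number from compound 1 to compound 3 (0.85 log units; beyond the scatter), the change being (methyl in place of oxolan-3-yl on an oxygen on an aromatic ring).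

Compound 4 `CCN(CC)c1ccc(/C=N/NC(=O)Nc2cc3c(Nc4ccc(F)c(Cl)c4)ncnc3cc2OC)c(O)c1` is not yet measured. It differs from compound 3 by diethylamino in place of hydroxy on an aromatic carbon; the place reads the same as in the change from compound 1 to compound 2, so this is the same change, now on the core of compound 3 rather than that of compound 1. Since the earlier step was a 3.5-fold higher number from compound 1 to compound 2 (0.54 log units; beyond the scatter), a step of similar size is expected here, a 2.8-fold higher number from compound 3 to compound 4 (0.45 log units; beyond the scatter). Compound 4 is therefore estimated at 90000 nM, with a range from 35000 nM to 250000 nM; a ceiling of this assay may be reached.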

Compound 4, half-maximal inhibitory concentration: 29300 nM
Compound 4: middle estimate off by 3.1-fold (0.49 log units), on the high side; measured number outside the range, below it.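

In this assay, diethylamino in place of hydroxy gives a 1.1-fold lower number from compound 3 to compound 4 (0.04 log units; within the scatter), so the step seen on the core of compound 1 does not carry over to the core of compound 3: the same change on two cores in this assay, a 3.5-fold higher number (0.54 log units; beyond the scatter) from compound 1 to compound 2 and a 1.1-fold lower number (0.04 log units; within the scatter) from compound 3 to compound 4, 3.8-fold (0.58 log units) apart, beyond the scatter of two such steps. Methyl in place of oxolan-3-yl gives a 1.9-fold higher number from compound 2 to compound 4 (0.27 log units; within the scatter), so the size of that change also depends on the group at the other place: the same change on two cores in this assay, a 7.1-fold higher number (0.85 log units; beyond the scatter) from compound 1 to compound 3 and a 1.9-fold higher number (0.27 log units; within the scatter) from compound 2 to compound 4, 3.8-fold (0.58 log units) apart, beyond the scatter of two such steps. These four compounds show that the two changes do not add up independently in this series, but they do not show why, and they give no rule for any other core.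

From the compounds shown here alone, whether another amine, such as dimethylamino, in place of hydroxy would follow compound 2 or compound 4 remains open. The same holds for an ethyl group or a longer chain in place of methyl on the oxygen.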